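Removing the Nitro Group from Compound 2

The source may report more compounds than this note shows. Statements on the series, on what has been measured and on what is new or still open speak of the compounds shown alone.

Compound 2 `CC(=O)N1N=C(c2ccc(F)cc2)CC1c1cn(-c2ccccc2)nc1-c1cccc([N+](=O)[O-])c1` gives 109% in a functional assay on the whole organism (Tail) with Rattus norvegicus as the target, in the tail flick test, with a stated time of 60 min, at a dose of 25 mg/kg by the oral route (on this read-out higher numbers stand for more inhibition at the one dose given (going by the name of the read-out) and lower numbers for less inhibition), the higher of the two numbers measured; compound 1 `CC(=O)N1N=C(c2ccc(F)cc2)CC1c1cn(-c2ccccc2)nc1-c1ccc(F)cc1` gives 43%. Compound 3 `CC(=O)N1N=C(c2ccc(F)cc2)CC1c1cn(-c2ccccc2)nc1-c1ccccc1` has not been measured. It differs from compound 2 by hydrogen in place of nitro on an aromatic carbon. For the measured compounds named here, the only measured step bearing on this change is a number 66 percentage points higher from compound 1 to compound 2 (beyond the scatter), which exchanged one group on that aromatic carbon for another; no measured step removes a nitro group alone. Because a number 66 percentage points higher from compound 1 to compound 2 (beyond the scatter) was large, a drop is expected on going to the unsubstituted phenyl, a number 54 percentage points lower from compound 2 to compound 3 (beyond the scatter). Compound 3 is therefore estimated at 55%, within 25% to 90%.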

Compound 3, a percentage reported as inhibition, in the whole organism at one dose (the size of the read-out at that dose, not a potency): 35%
The estimate for compound 3 lay 20 percentage points above the measured number; measured number inside the range.
By their numbers in this assay, from the lowest: compounds 3 and 1 (each within the scatter of the next); then compound 2.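

In this assay there is a number 74 percentage points lower from compound 2 to compound 3 (beyond the scatter) on removing the nitro group, so the high number of compound 2 depends on the 3-nitrophenyl group, not merely on the absence of the 4-fluorophenyl group. By contrast, there is a number 8 percentage points lower from compound 1 to compound 3 (within the scatter) with hydrogen in place of fluoro, so the phenyl and 4-fluorophenyl compounds cannot be told apart here. No measurement on hand explains the size of the nitro step. Going by these compounds, whether the high number requires a nitro group, or would also appear with an amine, a nitrile or a carboxylic acid on that ring, remains open.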